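Trifluoromethyl in Place of Chloro: an Expected Limit

This account rests on a few compounds, and the source may have more. Where it says the series, first, only, none or still open, it means among the compounds named here.

Compound 2 `O=C(Nc1cccc(-n2cc(-c3ccncc3)c(-c3ccc(Cl)c(O)c3)n2)c1)Nc1ccc(Cl)c(Cl)c1` is the measured anchor of this step. In a functional assay on A549 cells (Homo sapiens) for inhibition, read by sulforhodamine B assay, with a stated time of 48 h (on this read-out lower numbers stand for higher toxicity in this test and higher numbers for lower toxicity in this test), compound 2 gives > 32500 nM, which is a limit of the assay rather than a number. Compound 1 `COc1cc(-c2nn(-c3cccc(NC(=O)Nc4ccc(Cl)c(Cl)c4)c3)cc2-c2ccncc2)ccc1Cl` differs from compound 2 by hydrogen in place of methyl on an oxygen on an aromatic ring. In this assay compound 1 gives > 50000 nM, again a limit. The step that the two limits leave unreadable from compound 1 to compound 2 cannot be read in size, since both compounds sit at limits, as the limit of > 32500 nM in this assay, at which 1 of the 2 values shown sits, and the limit of > 50000 nM in this assay, at which 1 of the 2 values shown sits, show. Compound 3 `O=C(Nc1cccc(-n2cc(-c3ccncc3)c(-c3ccc(Cl)c(O)c3)n2)c1)Nc1ccc(Cl)c(C(F)(F)F)c1` carries the change (trifluoromethyl in place of chloro on an aromatic carbon). Going by the values given here, no measured step bears directly on this change, and the one measured step is unreadable, so the size of the step in this assay cannot be set from the numbers; no movement beyond the scatter is expected. Compound 3 is expected at 40000 nM, within 15000 nM to 100000 nM, most likely reported again as a limit. The expected step that the limit leaves unreadable from compound 2 to compound 3 is near zero.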

Compound 3, concentration lethal to 50% of the cells: > 32500 nM
Compound 3: only a limit was reported (the forecaster's own chance of this, stated with the estimate: 75%); the middle value does not contradict the limit.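

In this assay compound 3 gives > 32500 nM, a limit of the assay and not a number, so no step can be read between compound 2 and compound 3. The compounds shown leave open whether trifluoromethyl in place of chloro changes this read-out at all.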